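The compounds below may be only part of what the source reports. "The series", "measured", "known", "first", "only" and "open" are said of these compounds alone.

Two compounds in the series have a number in an in vitro ADME assay on microsomes from liver (Homo sapiens) for metabolic stability, tested at 5 uM; a lower number here means that the compound disappears faster, a higher number that the compound lasts longer. Compound 1 `CC(C)CCn1nc(-c2cccs2)c(O)c(C2=NS(=O)(=O)c3cc(OCC(N)=O)ccc3N2)c1=O` gives 0.383 h, and compound 2 `CC(=O)Nc1ccc2c(c1)S(=O)(=O)N=C(c1c(O)c(-c3cccs3)nn(CCC(C)C)c1=O)N2` gives 0.055 h, the lower of the two. Compound 3 `CC(C)CCn1nc(-c2cccs2)c(O)c(C2=NS(=O)(=O)c3cc(C#N)ccc3N2)c1=O` keeps the rest of compound 2 and differs in one place: cyano in place of acetamido on an aromatic carbon. Going by the values given here, only one measured step bears on this change: a 7.0-fold lower number from compound 1 to compound 2 (0.84 log units; beyond the scatter), with acetamido taking the place of carbamoylmethoxy. Acetamido has therefore been seen only in the lower of the two numbers, and no measured compound carries cyano. The data give no direct reading on the incoming group, and a single step is thin support for any trend. The working expectation in this assay is a rise of modest size, no larger than the measured step and possibly smaller, with the direction more secure than the size. The estimate corresponds to a 3.6-fold higher number from compound 2 to compound 3 (0.56 log units; beyond the scatter), an expected step that could fall close to the scatter at its low end. For compound 3 the expected half-life is 0.2 h, with an estimated range of 0.07 h to 0.6 h.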

Compound 3, half-life: 0.16 h
Beside the measured number, compound 3's estimate is 1.3-fold (0.10 log units) above it, and the stated range covers the measured number.
By their numbers in this assay, from the lowest: compound 2; then compound 3; then compound 1.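

In this assay the change on this aromatic carbon gives a 2.9-fold higher number from compound 2 to compound 3 (0.46 log units; beyond the scatter) and so puts a second group above acetamido, which until now had been compared only with carbamoylmethoxy. Cyano does not match carbamoylmethoxy, however, with a 2.4-fold lower number from compound 1 to compound 3 (0.38 log units; beyond the scatter) as the step, so the position now separates three groups into three levels, all beyond the scatter of one another: acetamido lowest, cyano in the middle and carbamoylmethoxy highest. The half-life is thus sensitive to the group at this one carbon with the rest of the structure held constant, but no measurement on these compounds accounts for the order of the three groups.

On these data alone, whether an amine, a carboxylic acid or a simple methoxy group at the same carbon would fall within this order or outside it remains open, and so does whether any group can exceed carbamoylmethoxy here. As far as these compounds go, all three compounds also carry the same remaining structure, so it is unknown whether the order holds when the thiophene or the chain on the shared core is replaced, for instance by a phenyl ring or a shorter chain.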